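Notes on the series: compound 1 to compound 4

A few compounds are considered here, and "the series" means these few. Any claim that something is new, unique, unknown or untested is made for them only; others in the source may bear on it.

Measured in a functional assay on SNB-19 cells (Homo sapiens) for inhibition, read by MTT assay, with a stated time of 7 days; a lower number here means a stronger inhibitor of growth, a higher number a weaker inhibitor of growth:
- compound 1 `C[Si](C)(C)CCOCn1nnc2c(C(N)=O)ncn2c1=O`: 29900 nM
- compound 2 `COc1ccc(Cn2nnc3c(C(N)=O)ncn3c2=O)c(OC)c1`: > 50000 nM, a limit
- compound 3 `COc1cc(Cn2nnc3c(C(N)=O)ncn3c2=O)cc(OC)c1OC`: > 50000 nM, a limit

Within the data shown here, compound 1 holds the only actual number in this small set. The other two compounds stand at the limit of > 50000 nM in this assay, at which 2 of the 3 values shown sit.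

The next compound is compound 4 `Cc1noc(Cn2nnc3c(C(N)=O)ncn3c2=O)n1`, and its change from compound 1 is a group of 6 heavy atoms (3 carbon, 2 nitrogen, 1 oxygen; one five-membered aromatic ring with 3 hetero atoms) in place of a group of 7 heavy atoms (5 carbon, 1 oxygen, 1 silicon; no ring), on a saturated chain carbon bound to an aromatic nitrogen.

No measured step connects any of these compounds. In this assay a small weakening is expected, possibly none beyond the scatter, as compound 2, which also carries a ring in this group, gives only the limit > 50000 nM. The estimated step is a 1.3-fold higher number from compound 1 to compound 4 (0.13 log units; within the scatter). For compound 4 the estimated value is 40000 nM, with an expected range of 18000 nM to 50000 nM.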

Compound 4, concentration for 50% growth inhibition: > 50000 nM
Compound 4: only a limit was reported; the forecaster's own chance of this, stated with the estimate: 45%; middle value at least 1.2-fold (0.09 log units) from the limit.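

In this assay the 3-methyl-1,2,4-oxadiazol-5-yl group on a saturated chain carbon bound to an aromatic nitrogen gives an at least 1.6-fold higher number from compound 1 to compound 4 (0.22 log units; that floor lies within the scatter), which fixes a floor and not a size. Compound 4 gives > 50000 nM, a limit and not a number. A five-membered aromatic ring with 3 hetero atoms in this place now also ends at the limit, as the two benzene-bearing compounds do: the limit of > 50000 nM in this assay, at which 3 of the 4 values shown sit.

Still open, going by these compounds, is whether any ring-bearing group here can give an actual number. Also open, on these data alone, is how a plain butyl chain or an amine on this chain would read.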